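A few compounds are considered here, and "the series" means these few. Any claim that something is new, unique, unknown or untested is made for them only; others in the source may bear on it.

Compound 1 `CCCCCCCCC(=O)N1c2ccccc2CC1C(=O)Nc1ccc(C(F)(F)F)cc1` gives > 10000 nM in a functional assay on MDA-MB-231 cells (Homo sapiens) for cytotoxicity (a lower number here means a stronger inhibitor of growth, a higher number a weaker inhibitor of growth), which is a limit of the assay rather than a number. Compound 2 `Cc1ccc(S(=O)(=O)N2c3ccccc3CC2C(=O)Nc2ccc(C(F)(F)F)cc2)cc1` gives > 10000 nM in this assay, again a limit.

Compound 2 therefore stands at the limit of this assay, as does compound 1: the step that the two limits leave unreadable from compound 1 to compound 2 cannot be read, since both ends sit at the limit of > 10000 nM in this assay, at which 2 of the 2 values shown sit. The next compound, compound 3 `Cc1ccc(S(=O)(=O)N2c3ccccc3CC2C(=O)Nc2cc(Cl)cc(Cl)c2)cc1`, differs from compound 2 at another place: 3,5-dichlorophenyl in place of 4-(trifluoromethyl)phenyl on an amide-type nitrogen. Going by the values given here, the only measured step concerns the group on the ring nitrogen, not the aryl amide, and its size is not readable, so no measured step speaks for a change of either direction in this assay beyond the scatter. Compound 3 is therefore estimated to remain at or near the limit, at 15000 nM with a range of 4000 nM to 60000 nM, which corresponds to an expected step that the limit leaves unreadable from compound 2 to compound 3.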

Compound 3, concentration for 50% growth inhibition: > 10000 nM
Compound 3: only a limit was reported; the forecaster's own chance of this, stated with the estimate: 80%; the middle value does not contradict the limit.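

Compound 3 gives > 10000 nM in this assay, which is a limit of the assay. The step from compound 2 to compound 3 therefore cannot be read: the limit of > 10000 nM in this assay, at which 3 of the 3 values shown sit.

The compounds shown leave open whether any change on the shared core would give a readable value in this assay.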